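A few compounds are considered here, and "the series" means these few. Any claim that something is new, unique, unknown or untested is made for them only; others in the source may bear on it.

In a functional assay (aorta) with Rattus norvegicus as the target (on this read-out higher numbers stand for an effect only at larger amounts of compound and lower numbers for an effect already at smaller amounts), compound 1 `COc1ccc(-c2nc(CNC(C)=O)sc2-c2ccc(OC)cc2)cc1` gives 8.1 uM and compound 2 `COc1ccc(-c2nc(CNC(=O)NC(C)C)sc2-c2ccc(OC)cc2)cc1` gives 5.7 uM, so compound 2 stands level with compound 1 within the scatter. Compound 3 `COc1ccc(-c2nc(C(=O)N3CCCCC3)sc2-c2ccc(OC)cc2)cc1` replaces the whole side chain of compound 2: (piperidin-1-yl)carbonyl in place of ((isopropylcarbamoyl)amino)methyl on an aromatic carbon. Going by the values given here, the only measured step, a 1.4-fold lower number from compound 1 to compound 2 (0.15 log units; within the scatter), exchanges just methyl for isopropylamino on a carbonyl carbon, so it bears only loosely on this larger change. Among the compounds with values here, no measured pair shows the new group. The step expected in this assay is a 1.2-fold higher number from compound 2 to compound 3 (0.09 log units; within the scatter), which is none beyond the scatter. For compound 3 the estimated value is 7 uM, with an expected range from 2.5 uM to 25 uM.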

Compound 3, concentration for half-maximal effect: 11 uM
Compound 3: the middle estimate sits 1.6-fold (0.20 log units) below what was measured; low and high end bracket the measured number.
By their numbers in this assay, from the lowest: compounds 2, 1 and 3 (each within the scatter of the next).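

In this assay, (piperidin-1-yl)carbonyl on this aromatic carbon stands level with both earlier side chains (a 1.9-fold higher number from compound 2 to compound 3 (0.29 log units; within the scatter); a 1.4-fold higher number from compound 1 to compound 3 (0.13 log units; within the scatter)). The position thus takes a side chain with a six-membered non-aromatic ring and 0 hydrogen-bond donors in place of ((isopropylcarbamoyl)amino)methyl, with no step beyond the scatter. Nothing available bears on why these numbers lie so close. As far as these compounds go, whether a carboxylic acid or a longer chain ending in an amine on this aromatic carbon would move the number beyond the scatter stays open, as does the effect of any change to the 4-methoxyphenyl groups.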